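The source may hold more compounds than are shown below. What is called first, only, known or untested is meant among the compounds shown, and "the series" means these compounds.

Compound 1: `Cc1cc(-c2nc3cc(F)c(F)cc3s2)ccc1N` — < 10 nM
Compound 2: `Nc1ccc(-c2nc3ccc(F)cc3s2)cc1Cl` — no result reported
Compound 3: `Cc1cc(-c2nc3cccc(F)c3s2)ccc1N` — 20 nM

Within the data shown here, in a functional assay on T47D cells (Breast, Homo sapiens) for inhibition (on this read-out higher numbers stand for weaker inhibition of growth and lower numbers for stronger inhibition of growth), compound 3 gives 20 nM, the only plain number among the three. For compound 1 the value < 10 nM is a limit of the assay, not a number; this is the limit of < 10 nM in this assay, at which 1 of the 3 values shown sits. Compound 2 has no result in this assay at all. The untested compound 4, `Cc1cc(-c2nc3ccccc3s2)ccc1N`, differs from compound 3 by hydrogen in place of fluoro on an aromatic carbon. Among the measured compounds shown here, with no measured step of this kind to lean on, the change is expected to move the value little, if at all: the step from compound 3 to compound 4 is estimated at a 1.3-fold higher number from compound 3 to compound 4 (0.10 log units; within the scatter), within the usual scatter. Compound 4 is therefore expected to give about 25 nM, somewhere between 10 nM and 60 nM.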

Compound 4, concentration for 50% growth inhibition: 20 nM
Beside the measured number, compound 4's estimate is 1.3-fold (0.10 log units) above it; measured number inside the range.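

In this assay, hydrogen in place of fluoro on an aromatic carbon gives no change at the digits printed from compound 3 to compound 4 (within the scatter). This is the first pair shown that differs in one place, and it shows that the fluoro at this position, ortho to a fused ring, is not needed for the growth inhibition seen with compound 3. Nothing at hand bears on why the two compounds read alike. What the compounds shown leave open is whether an amine or a methoxy group on this aromatic carbon would read as fluoro and hydrogen do.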